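A Methoxyphenyl Swap on a Weakly Active Core

This account rests on a few compounds, and the source may have more. Where it says the series, first, only, none or still open, it means among the compounds named here.

Measured so far:
Compound 1 `COc1ncc(-c2ccc3c(c2)N(C2CC2)C(=O)CO3)cc1NS(=O)(=O)c1ccc(F)cc1` gives 3320 nM in a functional assay on A549 cells (Homo sapiens) for antiproliferative activity, read by MTT assay, with a stated time of 72 h; on this read-out higher numbers stand for weaker inhibition and lower numbers for stronger inhibition.
Compound 3 `COc1ccc(N2C(=O)COc3ccc(-c4cnc(OC)c(NS(=O)(=O)c5ccc(F)cc5)c4)cc32)cc1` gives 1350 nM in this assay.
Compound 2 `O=C1COc2ccc(-c3cccc(NS(=O)(=O)c4ccc(F)cc4)c3)cc2N1C1CC1` reaches only the limit of this assay, > 40000 nM, and not a number.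

The change from compound 1 to compound 3 is 4-methoxyphenyl in place of cyclopropyl on an amide-type nitrogen in a ring. It gave a 2.5-fold lower number from compound 1 to compound 3 (0.39 log units; beyond the scatter). Compound 4 `COc1ccc(N2C(=O)COc3ccc(-c4cccc(NS(=O)(=O)c5ccc(F)cc5)c4)cc32)cc1` is not yet measured; it differs from compound 2 by 4-methoxyphenyl in place of cyclopropyl on an amide-type nitrogen in a ring, the same change at the same place. The difference between the core of compound 1 and the core of compound 2 is not broken down here.

As far as these compounds go, compound 2 sits at the limit of > 40000 nM in this assay, at which 1 of the 3 values shown sits, so its true value is unknown beyond that. Should the change act as it did before, a modest improvement in this assay would be expected, and the step from compound 2 to compound 4 is estimated at an at least 1.3-fold lower number from compound 2 to compound 4 (0.12 log units; that floor lies within the scatter) because of a 2.5-fold lower number from compound 1 to compound 3 (0.39 log units; beyond the scatter). Since the starting point is a limit, compound 4 may itself only reach a limit. Compound 4 is therefore expected near 30000 nM, with a likely range of 10000 nM to 80000 nM.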

Compound 4, half-maximal inhibitory concentration: 38200 nM
Compound 4: middle estimate off by 1.3-fold (0.10 log units), on the low side; the range from low to high includes it.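

In this assay, placing 4-methoxyphenyl where cyclopropyl stood on the core of compound 2 gave an at least 1.0-fold lower number from compound 2 to compound 4 (0.01 log units; that floor lies within the scatter), so this core shows no gain that can be told from the usual scatter. Compound 2 has a limit of the assay and not a number: > 40000 nM. Its true value could therefore lie far from the limit, so these data neither show that the change carries over from one core to the other at the same size nor show that it fails to: the same change on two cores in this assay, a 2.5-fold lower number (0.39 log units; beyond the scatter) from compound 1 to compound 3 and an at least 1.0-fold lower number (0.01 log units; that floor lies within the scatter) from compound 2 to compound 4; the limit leaves it open whether they differ.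

As far as these compounds go, only cyclopropyl and 4-methoxyphenyl appear here on the amide-type nitrogen, so it remains open how a plain phenyl, a longer chain or an amine would behave at that place on either core. The difference between the core of compound 1 and the core of compound 2 also remains unresolved, as the compounds shown do not break it down into single changes.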